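This account rests on a few compounds, and the source may have more. Where it says the series, first, only, none or still open, it means among the compounds named here.

Measured compounds:
compound 1 `COc1ccc(C2CC(c3ccccc3)=NN2C2=NC(=O)/C(=C3\C(=O)Nc4ccc(Br)cc43)S2)cc1` gives 190 nM
compound 2 `COc1ccc(C2=NN(C3=NC(=O)/C(=C4\C(=O)Nc5ccc(Br)cc54)S3)C(c3ccc(OC)cc3)C2)cc1` gives 200 nM
compound 3 `O=C1N=C(N2N=C(c3ccccc3)CC2c2ccc(Cl)cc2)S/C1=C1/C(=O)Nc2ccccc21` gives 190 nM

In a functional assay on cells (Cancer cell lines, Homo sapiens) for cytotoxicity, read by sulforhodamine B assay, with a stated time of 48 h (a higher number here means a weaker inhibitor of growth, a lower number a stronger inhibitor of growth), compound 1 and compound 2 lie close together. The change between them, (methoxy in place of hydrogen on an aromatic carbon), gave a 1.1-fold higher number from compound 1 to compound 2 (0.02 log units; within the scatter). Compound 3 differs from compound 1 in more than one place, so the difference between the two cores is not broken down here; what the two values show is that compound 3 stands level with compound 1 at the digits given, and the gap to compound 2 is within the scatter.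

Compound 4 `COc1ccc(C2=NN(C3=NC(=O)/C(=C4\C(=O)Nc5ccccc54)S3)C(c3ccc(Cl)cc3)C2)cc1` has not yet been measured. Going by the values given here, it is made from compound 3 by the same change, (methoxy in place of hydrogen on an aromatic carbon), at a place described in the same words as the one between compound 1 and compound 2. Among the compounds with values here, for compound 4 the step from compound 3 is expected to be a 1.1-fold higher number from compound 3 to compound 4 (0.02 log units; within the scatter), resting on the single earlier step of a 1.1-fold higher number from compound 1 to compound 2 (0.02 log units; within the scatter), which was within the scatter. Compound 4 is therefore estimated at 200 nM, with a likely range from 110 nM to 380 nM.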

Compound 4, concentration for 50% growth inhibition: 100000 nM
Estimate against measurement, compound 4: 500-fold (2.70 log units) below; measured number above the stated range.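

In this assay, the change from phenyl to 4-methoxyphenyl did not carry over from one core to the other. On the core of compound 3 it gave a 530-fold higher number from compound 3 to compound 4 (2.72 log units; beyond the scatter), and the two steps set side by side disagree: the same change on two cores in this assay, a 1.1-fold higher number (0.02 log units; within the scatter) from compound 1 to compound 2 and a 530-fold higher number (2.72 log units; beyond the scatter) from compound 3 to compound 4, 500-fold (2.70 log units) apart, beyond the scatter of two such steps
This shows that, in this series, the near absence of an effect on the core of compound 1 is no guide to the effect of the same change on the core of compound 3, but it does not show which difference between the cores is responsible, as they differ in more than one place and each is represented by a single pair.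

Going by these compounds, it remains open whether a hydroxy group, an ethoxy group or an amine in place of the methoxy would give a step as large on the core of compound 3. Also open, on these data alone, is whether the step would stay this large with a bromo group added to that core and the chloro group kept.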